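The source may report more compounds than this note shows. Statements on the series, on what has been measured and on what is new or still open speak of the compounds shown alone.

The two measured compounds frame the question. Compound 1 `N[C@H](CN(C(=O)[C@@H]1C[C@H]1c1ccccc1)c1ccc(-c2ccccc2)cc1)C1CCCCC1` carries a cyclohexyl group beside the amine and an unsubstituted phenyl ring on the cyclopropane; in a functional assay for agonist activity at G protein-coupled receptor 88 (Homo sapiens), read by HTRF and cAMP accumulation (on this read-out higher numbers stand for an effect only at larger amounts of compound and lower numbers for an effect already at smaller amounts), compound 1 gives 0.66 nM. Compound 2 `CC[C@H](C)[C@H](N)CN(C(=O)[C@@H]1C[C@H]1c1ccc(OC)cc1)c1ccc(-c2ccccc2)cc1` has a sec-butyl group in place of the cyclohexyl and a 4-methoxyphenyl ring on the cyclopropane. For compound 2 this assay reports only a limit, > 25000 nM; this is the limit of > 25000 nM in this assay, at which 1 of the 2 values shown sits, and no number is known for it. Two places differ between compound 1 and compound 2. The two values show only that one is a potent agonist and the other gives no measurable response.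

Compound 3 `CC[C@H](C)[C@H](N)CN(C(=O)[C@@H]1C[C@H]1c1ccsc1)c1ccc(-c2ccccc2)cc1` keeps the sec-butyl group and changes the cyclopropane substituent: thiophen-3-yl in place of 4-methoxyphenyl on a saturated ring carbon. With compound 2 at a limit, the step can only be toward lower concentrations or nowhere at all. He expects a step of an at least 12-fold lower number from compound 2 to compound 3 (1.09 log units; beyond the scatter), moving compound 3 into the measurable range of this assay but without reaching compound 1. For compound 3 he estimates 2000 nM, within a range from 50 nM to 25000 nM.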

Compound 3, half-maximal effective concentration: 450 nM
Compound 3: the middle estimate sits 4.4-fold (0.65 log units) above what was measured; the range from low to high includes it.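

With the sec-butyl group held constant, the substituent on the cyclopropane proves decisive on its own in this assay: replacing 4-methoxyphenyl with thiophen-3-yl gives an at least 55-fold lower number from compound 2 to compound 3 (1.74 log units; beyond the scatter). Compound 3 gives 450 nM, which shows that a compound with the sec-butyl group can produce a measurable response, so that group alone does not settle the outcome at this receptor. The true size of the step remains unknown because compound 2 stands at a limit and not at a number: the limit of > 25000 nM in this assay, at which 1 of the 3 values shown sits.

Compound 1 and compound 3 differ in two places, so the compounds shown cannot separate the contribution of the cyclohexyl group from that of the ring on the cyclopropane. Going by these compounds, it also remains open whether the methoxy group or the six-membered aromatic ring separates compound 2 from compound 3, and how an unsubstituted phenyl, a 4-fluorophenyl or a pyridin-3-yl group on this saturated ring carbon would read alongside the sec-butyl group.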